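Ester Analogues and Hepatocyte Half-Life: Pyridyl for Tolyl

A few compounds are considered here, and "the series" means these few. Any claim that something is new, unique, unknown or untested is made for them only; others in the source may bear on it.

Measured compounds:
- compound 1 `CC(=O)NC1CCC(CN2CCN(c3cc(=O)c4cc(C(F)(F)F)cc([N+](=O)[O-])c4s3)CC2)CC1` — in an ADME assay on cells (Hepatocyte, Homo sapiens) for metabolic stability (a lower number here means that the compound disappears faster, a higher number that the compound lasts longer), compound 1 gives > 1.55 h
- compound 2 `COc1ccc(C(=O)OC2CCC(CN3CCN(c4cc(=O)c5cc(C(F)(F)F)cc([N+](=O)[O-])c5s4)CC3)CC2)cc1` — compound 2 gives 0.165 h
- compound 3 `Cc1ccc(C(=O)OC2CCC(CN3CCN(c4cc(=O)c5cc(C(F)(F)F)cc([N+](=O)[O-])c5s4)CC3)CC2)cc1` — compound 3 gives 0.148 h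

The value of compound 1 is a limit of this assay, not a number (the limit of > 1.55 h in this assay, at which 1 of the 3 values shown sits). Against that limit, the two esters fall away: an at least 9.3-fold lower number from compound 1 to compound 2 (0.97 log units; beyond the scatter) and an at least 10-fold lower number from compound 1 to compound 3 (1.02 log units; beyond the scatter). Between the two esters themselves the change of the ring substituent did little: a 1.1-fold lower number from compound 2 to compound 3 (0.05 log units; within the scatter). Compound 3 therefore stands with the lowest of the two numbers shown, with compound 2 within the scatter beside it.

Compound 4 `O=C(OC1CCC(CN2CCN(c3cc(=O)c4cc(C(F)(F)F)cc([N+](=O)[O-])c4s3)CC2)CC1)c1ccncc1` is not yet measured. It differs from compound 3 in one place: pyridin-4-yl in place of 4-methylphenyl on a carbonyl carbon. Going by the values given here, the ester linkage that compound 2 and compound 3 share is kept, and the only measured step that bears on such a swap of the aromatic ring is the one from compound 2 to compound 3, which stayed within the scatter. The account therefore expects no step beyond the scatter for compound 4 in this assay, a 1.4-fold higher number from compound 3 to compound 4 (0.13 log units; within the scatter). Compound 4 is estimated at 0.2 h, within the range of 0.08 h to 0.5 h.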

Compound 4, half-life: 0.075 h
Beside the measured number, compound 4's estimate is 2.7-fold (0.43 log units) above it; measured number below the stated range.
By their numbers in this assay, from the lowest: compounds 4, 3 and 2 (each within the scatter of the next, the first and the last beyond it). At a limit, above all of these: compound 1.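

In this assay, going by these compounds alone, the pyridin-4-yl group on the carbonyl carbon gives the first step among the esters that lies beyond the scatter, a 2.2-fold lower number from compound 2 to compound 4 (0.34 log units; beyond the scatter), yet the comparison with the 4-methylphenyl ester stays within it, a 2.0-fold lower number from compound 3 to compound 4 (0.30 log units; within the scatter), so the aromatic ring on this carbonyl carbon has only a modest reach, and only one of the two ester comparisons shows it. The exchange of acetamido for the ester remains much the larger change at the saturated ring carbon, now also with pyridin-4-yl on the carbonyl carbon: an at least 20-fold lower number from compound 1 to compound 4 (1.31 log units; beyond the scatter). The value of compound 1 is a limit of the assay, not a number: the limit of > 1.55 h in this assay, at which 1 of the 4 values shown sits.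

From the compounds shown here alone, what remains open is whether the ester linkage itself or the aromatic ring it carries sets these short half-lives, a question that an amide bearing pyridin-4-yl on its carbonyl carbon would address. Also open, going by these compounds, is whether the ring nitrogen's placement matters, as a pyridin-3-yl group would show, and the values shown give no cause for any of these steps.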